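The source may report more compounds than this note shows. Statements on the series, on what has been measured and on what is new or still open speak of the compounds shown alone.

Compound 1, `Cc1ccccc1-c1nc(CN2CCC(C(=O)N3CCN(C4CCN(C)CC4)CC3)CC2)c(C)o1`, in a physicochemical assay for permeability, using PAMPA; a lower number here means that the compound crosses the layer more slowly, a higher number that the compound crosses the layer faster: < 3.2 10^-6 cm/s, which is a limit of the assay and not a number.
Compound 2, `Cc1cccc(F)c1-c1nc(CN2CCC(C(=O)NCCCN3C[C@H](C)C[C@H](C)C3)CC2)c(C)o1`, in this assay: 234 10^-6 cm/s.

Compound 2 therefore holds the only numerical result; the remaining value shown is the limit of < 3.2 10^-6 cm/s in this assay, at which 1 of the 2 values shown sits. Compound 3, `COc1ccc(-c2nc(CN3CCC(C(=O)NCCCN4C[C@H](C)C[C@H](C)C4)CC3)c(C)o2)cc1OC`, awaits measurement in this assay. Its structure carries one change from compound 2: 3,4-dimethoxyphenyl in place of 2-fluoro-6-methylphenyl on an aromatic carbon. Among the measured compounds shown here, no step between measured compounds is available to guide the size of this change, so the expectation for compound 3 is held loosely, with a modest drop thought more likely than a rise. Compound 3 is expected to give 120 10^-6 cm/s, within 40 10^-6 cm/s to 300 10^-6 cm/s. That estimate implies a 2.0-fold lower number from compound 2 to compound 3 (0.29 log units; within the scatter).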

Compound 3, apparent permeability: 81.9 10^-6 cm/s
For compound 3 the middle estimate is 1.5-fold (0.17 log units) above the measured one, within the range that was stated.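

Placing 3,4-dimethoxyphenyl where 2-fluoro-6-methylphenyl stood gives the first readable step at this position in this assay: a 2.9-fold lower number from compound 2 to compound 3 (0.46 log units; beyond the scatter). So this one change moves the number modestly, yet beyond the scatter. No measurement shown explains why the number moves.

Going by these compounds, whether one methoxy group alone would give the same step remains open, as does the separate part of the fluorine and the methyl. A plain phenyl or a pyridine ring at this position would test how far the step extends.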